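A few compounds are considered here, and "the series" means these few. Any claim that something is new, unique, unknown or untested is made for them only; others in the source may bear on it.

Measured in an assay on isolated protein for inhibition of DNA topoisomerase 1 (Homo sapiens), with a stated time of 30 min, tested at 100 uM; a higher number here means a stronger effect of the compound at the concentration tested, a lower number a weaker effect:

- compound 1 `Oc1cccc(-c2cc(-c3ccncc3)nc(-c3ccccc3Cl)c2)c1`: 0%
- compound 2 `Oc1cccc(-c2cc(-c3ccncc3)nc(-c3cccc(Cl)c3)c2)c1`: 0%
- compound 3 `Oc1ccc(-c2cc(-c3ccncc3)nc(-c3ccccc3Cl)c2)cc1`: 9.9%

Compound 1 stands level with compound 2 at the digits reported, the two together the lowest of the three numbers; its nearest neighbour is compound 2, no change at the digits printed from compound 1 to compound 2 (within the scatter), and its furthest is compound 3, a number 9.9 percentage points higher from compound 1 to compound 3 (within the scatter), both steps within the scatter. Nothing in this set of three separates itself from the rest beyond the scatter.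

Compound 4 `Oc1cccc(-c2cc(-c3cccnc3)nc(-c3ccccc3Cl)c2)c1` is not yet measured. It differs from compound 1 in one place: pyridin-3-yl in place of pyridin-4-yl on an aromatic carbon. Neither measured step touches this group. The step from compound 1 to compound 2 moves the chlorophenyl substituent, the step from compound 1 to compound 3 moves the hydroxyphenyl substituent, and each of them leaves the read-out within the scatter. Both give reason to expect that a single change on the shared core, leaving everything else in place, produces no step beyond the scatter, though no measured pair bears on the pyridinyl group itself.

The expected step is therefore a number 3 percentage points higher from compound 1 to compound 4 (within the scatter), no change beyond the scatter. Compound 4 is estimated at 3%, with a range from 0% to 15%.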

Compound 4, a percentage reported as inhibition, at one concentration (the size of the read-out at that concentration, not a potency): 0%
For compound 4 the middle estimate is 3 percentage points above the measured one; low and high end bracket the measured number.
By their numbers in this assay, from the lowest: compounds 1, 2, 4 and 3 (each within the scatter of the next).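

In this assay, among these compounds, pyridin-3-yl in place of pyridin-4-yl gives no change at the digits printed from compound 1 to compound 4 (within the scatter), so this position now has a measured step of its own, whereas the earlier pairs touched only the chlorophenyl and hydroxyphenyl groups. The two groups have the same heavy atoms, hydrogen-bond donors and acceptors, so this pair shows that joining the same ring differently at this position, on an aromatic carbon next to the ring nitrogen of the shared core, opens no gap beyond the scatter; since compound 4 gives 0%, however, the read-out has no room to show any weakening. No measurement at hand explains the result at this position.

Still open, on these data alone, is whether a different group at this position, such as pyridin-2-yl, an aminomethyl group or a carboxylic acid, would move the read-out in this assay beyond the scatter. Also open is whether any single change to the shared core can lift the read-out clear of the scatter at the tested concentration, as no step shown so far does so.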